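Trimethoxyphenyl benzimidazoles: aryl variation at the fused ring

A few compounds are considered here, and "the series" means these few. Any claim that something is new, unique, unknown or untested is made for them only; others in the source may bear on it.

Measured so far:
- compound 1 `COc1cc(-n2cnc3ccc(-c4cccc(C)c4C)cc32)cc(OC)c1OC`: 3040 nM
- compound 2 `COc1cc(-n2cnc3ccc(-c4ccccc4)cc32)cc(OC)c1OC`: 290 nM
- compound 3 `COc1cc(-n2cnc3ccc(-c4cccc([N+](=O)[O-])c4)cc32)cc(OC)c1OC`: 380 nM

In a functional assay on SGC-7901 cells (Homo sapiens) for antiproliferative activity, read by MTT assay, with a stated time of 72 h (a higher number here means a weaker inhibitor, a lower number a stronger inhibitor), compound 3 stands second highest of the three numbers, nearest to compound 2 and furthest from compound 1; the step of a 1.3-fold higher number from compound 2 to compound 3 (0.12 log units; within the scatter) lies within the scatter, whereas an 8.0-fold lower number from compound 1 to compound 3 (0.90 log units; beyond the scatter) lies beyond it.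

Compound 4 `COc1cc(-n2cnc3ccc(-c4ccc(O)cc4)cc32)cc(OC)c1OC` is not yet measured. Its change from compound 3: 4-hydroxyphenyl in place of 3-nitrophenyl on an aromatic carbon. Within the data shown here, no measured step covers a 4-hydroxyphenyl group. Among the measured compounds shown here, the only step touching the same ring position pattern, a 1.3-fold higher number from compound 2 to compound 3 (0.12 log units; within the scatter), was within the scatter, so a small aryl substituent is expected to leave the number near that of compound 3. A step of a 1.1-fold higher number from compound 3 to compound 4 (0.02 log units; within the scatter) is therefore expected. Compound 4 is estimated at 400 nM, with a range of 150 nM to 1500 nM.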

Compound 4, half-maximal inhibitory concentration: > 10000 nM
Compound 4 was reported as a limit; the forecaster's own chance of this, stated with the estimate: 5%; at least 25-fold (1.39 log units) between middle value and limit.
By their numbers in this assay, from the lowest: compounds 2 and 3 (each within the scatter of the next); then compound 1. At a limit, above all of these: compound 4.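

In this assay compound 4 is reported only as a limit, > 10000 nM. Substitution on the phenyl group is therefore not always silent at this position: hydroxy in place of hydrogen gives an at least 34-fold higher number from compound 2 to compound 4 (1.53 log units; beyond the scatter), and 4-hydroxyphenyl in place of 3-nitrophenyl gives an at least 26-fold higher number from compound 3 to compound 4 (1.42 log units; beyond the scatter), although nitro in place of hydrogen stayed within the scatter. The change from 2,3-dimethylphenyl, the weakest group until now, still gives an at least 3.2-fold higher number from compound 1 to compound 4 (0.51 log units; beyond the scatter).

From the compounds shown here alone, it remains open whether 3-hydroxyphenyl, 4-methoxyphenyl or 4-aminophenyl groups behave like compound 4, so the loss cannot yet be assigned to the hydroxy group or to its place on the ring.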